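Compound 3 to compound 4: a halogen swap

A few compounds are considered here, and "the series" means these few. Any claim that something is new, unique, unknown or untested is made for them only; others in the source may bear on it.

In a physicochemical assay for lipophilicity, read by mass spectrometry (a higher number here means a more lipophilic compound, a lower number a more polar compound), compound 1 (`COc1cc2c(cc1OC)C(=O)C(C(=O)Nc1ccc(F)cc1)C2`) reads 2.36 while compound 2 (`COc1cc2c(cc1OC)C(=O)C(C(=O)Nc1ccc(Cl)cc1)C2`) reads 2.76 and compound 3 (`COc1cc2c(cc1OC)C(=O)C(C(=O)Nc1cccc(Cl)c1)C2`) reads 2.76 and so stands level with compound 2, together the highest of the three numbers. Compound 4 (`COc1cc2c(cc1OC)C(=O)C(C(=O)Nc1ccccc1Br)C2`) has 2-bromophenyl in place of 3-chlorophenyl on an amide-type nitrogen and is not yet measured. Chloro in place of fluoro gave a number 0.40 log units higher from compound 1 to compound 2 (beyond the scatter) as the nearest guide to a halogen change, and 3-chlorophenyl in place of 4-chlorophenyl gave no change at the digits printed from compound 2 to compound 3 (within the scatter) as the guide to a moved halogen. Among the measured compounds shown here, no measured step contains 2-bromophenyl. No step beyond the scatter is expected, with a number 0.09 log units higher from compound 3 to compound 4 (within the scatter) as the estimated step in this series. For compound 4 the estimated value is 2.85 with an expected range from 2.5 to 3.2 on this scale.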

Compound 4, partition coefficient: 3.03
For compound 4 the middle estimate is 0.18 log units below the measured one; measured number inside the range.
By their numbers in this assay, from the lowest: compound 1; then compounds 2, 3 and 4 (each within the scatter of the next).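

In this assay, 2-bromophenyl on the amide-type nitrogen gives a number 0.27 log units higher from compound 3 to compound 4 (within the scatter) and a number 0.27 log units higher from compound 2 to compound 4 (within the scatter), so the data do not separate it from either chlorophenyl group. Against 4-fluorophenyl it gives a number 0.67 log units higher from compound 1 to compound 4 (beyond the scatter), which leaves compound 1 apart from the other three. Nothing measured here accounts for these steps.

Still open, going by these compounds, is how 4-bromophenyl, or a phenyl carrying an amine or a carboxylic acid, would read in this assay on the same amide-type nitrogen. The set also leaves open whether any group at this place falls outside the span from compound 1 to compound 4.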